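Estimating lipophilicity for a compound with a missing neighbour

This account rests on a few compounds, and the source may have more. Where it says the series, first, only, none or still open, it means among the compounds named here.

Values so far in a physicochemical assay for lipophilicity, read by HPLC, at pH 7.4; on this read-out lower numbers stand for lower lipophilicity and higher numbers for higher lipophilicity
- compound 1 `O=C(O)COc1ccc([C@H]2CC[C@]3(CC2)OOC2(O3)C3CC4CC2CC(C3)C4O)cc1` gives 1.7
- compound 2 `O=C(O)CNC(=O)COc1ccc([C@H]2CC[C@]3(CC2)OOC2(O3)C3CC4CC(C3)CC2C4)cc1` gives 3
- compound 3 `O=C(O)CN1CCC(Oc2ccc([C@H]3CC[C@]4(CC3)OOC3(O4)C4CC5CC(C4)CC3C5)cc2)CC1` gives "not determined" (no result reported)

Lipophilicity describes how strongly a compound favours a fat-like environment over water. The next compound to be tested is compound 4 `O=C(O)CCCOc1ccc([C@H]2CC[C@]3(CC2)OOC2(O3)C3CC4CC(C3)CC2C4)cc1`, and its closest comparison by structure is compound 3. That comparison has a weakness, since the entry for compound 3 is "not determined" (no result reported) and gives no number to start from.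

The structural change is 3-carboxypropyl in place of 1-(carboxymethyl)piperidin-4-yl on an oxygen on an aromatic ring. In words, 3-carboxypropyl takes the place of 1-(carboxymethyl)piperidin-4-yl on an oxygen on an aromatic ring.

With no starting value, the size of this step in this assay cannot be read from compound 3. The nearest guide is compound 2 at 3, which has the same core as compound 4. The core of compound 1 differs, so compound 1 at 1.7 is a weaker guide. Compound 4 is therefore expected to land close to compound 2, with no step in either direction beyond the usual scatter. For compound 4 the estimated value is 2.9, with an expected range of 2.3 to 3.6.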

Compound 4, distribution coefficient: 3.6
Compound 4: middle estimate off by 0.70 log units, on the low side; measured number inside the range.
By their numbers in this assay, from the lowest: compound 1; then compound 2; then compound 4.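

In this assay, within the data shown here, putting 2-carboxyethyl in place of (carboxymethyl)carbamoyl on a saturated chain carbon bound to an oxygen on an aromatic ring gives a number 0.60 log units higher from compound 2 to compound 4 (beyond the scatter), the first step in this set that can be read. It shows that this read-out responds to a change in the chain alone: the shared core stays the same, and both chains still carry a carboxylic acid. Nothing measured here explains why the number moves with this change.

From the compounds shown here alone, compound 3 has no number in this assay, so the step to compound 4, where 3-carboxypropyl replaces 1-(carboxymethyl)piperidin-4-yl, cannot be read, and the size of that change remains unknown. Among these compounds, the single readable step also cannot say how a longer chain, a methyl ester in place of the carboxylic acid, or a primary amine on the chain would read on the shared core, or whether the step would keep its size on the core of compound 1.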